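The source may hold more compounds than are shown below. What is called first, only, known or untested is meant among the compounds shown, and "the series" means these compounds.

Compound 2, with the structure `N/C(=N\C(=O)CC(c1ccccc1)c1ccccc1)NCCCc1ncc[nH]1`, gives 6.13 in a functional assay on Sf9 cells for antagonist activity at histamine H2 receptor (Homo sapiens), with stated times of 2 min and 20 min (a lower number here means a less potent compound, a higher number a more potent compound, by a factor of ten per unit of this negative logarithm), and this is the higher of the two numbers obtained so far. For the measured compounds named here, the only other measured compound, compound 1 with the structure `CC(CC(=O)/N=C(\N)NCCCc1ncc[nH]1)c1ccccc1`, gives 5.3 in this assay, and the single known step, a number 0.83 log units higher from compound 1 to compound 2 (beyond the scatter), comes from placing a phenyl where a methyl stood. Compound 3, with the structure `N/C(=N\C(=O)CC(c1ccccc1)c1nccs1)NCCCc1ncc[nH]1`, differs from compound 2 in a single place: 1,3-thiazol-2-yl in place of phenyl on a saturated chain carbon bound to an aromatic carbon and a saturated chain carbon. Going by the values given here, no measured pair covers an exchange of one aromatic ring for another at this position, so the step from compound 1 to compound 2 bears on it only in showing that an aromatic group at this carbon is tolerated and favoured over a small alkyl group. On that basis compound 3 is expected to stay close to compound 2, with an estimated step of a number 0.07 log units higher from compound 2 to compound 3 (within the scatter) in this assay, within the usual scatter. The estimate for compound 3 is therefore 6.2, expected to fall between 5.6 and 6.8.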

Compound 3, negative logarithm of the antagonist equilibrium constant: 5.19
Compound 3: middle estimate off by 1.01 log units, on the high side; measured number below the stated range.
By their numbers in this assay, from the lowest: compounds 3 and 1 (each within the scatter of the next); then compound 2.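

The earlier pair showed phenyl favoured over methyl at this saturated chain carbon, but compound 3 shows that this gain does not carry over to every aromatic ring there: in this assay the exchange of phenyl for 1,3-thiazol-2-yl gives a number 0.94 log units lower from compound 2 to compound 3 (beyond the scatter) and so removes an amount comparable to the gain seen earlier. Set against the methyl group, the same ring gives a number 0.11 log units lower from compound 1 to compound 3 (within the scatter) and so offers no measurable advantage over methyl in this read-out, which means that an aromatic ring at this carbon is not enough on its own to reach the number of compound 2. Nothing available here accounts for the loss, as no supporting measurement bears on it.

The step from compound 2 to compound 3 changes ring size and hetero atoms together, so the compounds shown cannot separate the two, and a thiophen-2-yl or a pyridin-2-yl group on this carbon would bear directly on that question. They also leave open whether an aromatic ring is needed there at all, which a saturated cyclohexyl group in place of phenyl would test.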